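The source may report more compounds than this note shows. Statements on the series, on what has been measured and on what is new or still open speak of the compounds shown alone.

Measured compounds:
Compound 1 `CNC(=O)c1cc(C(=O)NC2CC2)cn(Cc2ccc(F)cc2)c1=O` gives 3.2 in a physicochemical assay for lipophilicity, at pH 7.4; on this read-out lower numbers stand for lower lipophilicity and higher numbers for higher lipophilicity.
Compound 2 `CNC(=O)c1cc(C(=O)NCCO)cn(Cc2ccccc2)c1=O` gives 1.9 in this assay.

Of the two numbers in hand, compound 1 stands highest; its nearest neighbour is compound 2, whose value lies lower by a gap that is beyond the usual scatter. Among the measured compounds shown here, no step between measured compounds differing in a single place is available, so the unmeasured compound 3 `CNC(=O)c1cc(C(=O)NC2CC2)cn(Cc2cccc(C#N)c2)c1=O` can only be judged from its own change relative to compound 1: 3-cyanophenyl in place of 4-fluorophenyl on a saturated chain carbon bound to an aromatic nitrogen. For the measured compounds named here, nothing among the measured pairs isolates this exchange, so any forecast rests on the change itself. A downward step in this assay is expected, of moderate size, larger than the scatter, so that compound 3 should settle between the two measured values. The step from compound 1 to compound 3 is estimated at a number 0.70 log units lower from compound 1 to compound 3 (beyond the scatter). Compound 3 is expected to give about 2.5, within a range of 2 to 3.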

Compound 3, distribution coefficient: 2.6
Compound 3: middle estimate off by 0.10 log units, on the low side; the measured number falls inside the stated range.
By their numbers in this assay, from the lowest: compound 2; then compound 3; then compound 1.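

The exchange of 4-fluorophenyl for 3-cyanophenyl, on a saturated chain carbon bound to an aromatic nitrogen, gives a number 0.60 log units lower from compound 1 to compound 3 (beyond the scatter), the first single-place step available in this assay. The earlier pair differed in more than one place, so its gap could not be assigned to any one part of the molecule, whereas this step shows that a change at this position alone is enough to move the read-out beyond the usual scatter. Nothing measured here explains the size or direction of this step.

Among the compounds shown here, the single step does not separate the loss of the fluorine from the gain of the nitrile, so the contribution of each stays open. Also open, from the compounds shown here alone, is how this assay would read with an amine or a carboxylic acid on the aromatic ring at this position.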